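This account rests on a few compounds, and the source may have more. Where it says the series, first, only, none or still open, it means among the compounds named here.

Compound 1 `COc1cc(-c2cc(/C=C/C(=O)c3ccc(N)cc3)[nH]n2)cc(OC)c1OC`: 98%
Compound 2 `COc1ccc(C(=O)/C=C/c2cc(-c3cc(OC)c(OC)c(OC)c3)n[nH]2)cc1OC`: 92%

Of the compounds shown here, two have been measured in a functional assay on LOX IMVI cells (Homo sapiens) for cytotoxicity, read by sulforhodamine B assay, with a stated time of 48 h, tested at 0.01 uM; on this read-out higher numbers stand for a weaker effect at the one concentration tested and lower numbers for a stronger effect. Compound 1 gives 98% and compound 2 gives 92%. Compound 2 holds the lowest of the two numbers; its nearest neighbour is compound 1, and the step of a number 6 percentage points lower from compound 1 to compound 2 (within the scatter) lies within the scatter, so the two cannot be told apart on these numbers.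

Compound 3 `COc1cc(C(=O)/C=C/c2cc(-c3cc(OC)c(OC)c(OC)c3)n[nH]2)cc(OC)c1OC` is compound 2 with one change: methoxy in place of hydrogen on an aromatic carbon. Within the data shown here, the only measured step, a number 6 percentage points lower from compound 1 to compound 2 (within the scatter), concerns a different change, the group on the carbonyl carbon, and even that step stayed within the scatter. Among the measured compounds shown here, no measured step bears directly on a methoxy in place of hydrogen on an aromatic carbon, so no step beyond the scatter is expected here. Compound 3 is expected to give 93%, with a range from 82% to 104%. The expected step of a number 1 percentage points higher from compound 2 to compound 3 (within the scatter) is therefore close to nothing.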

Compound 3, a percentage reported as activity, at one concentration (the size of the read-out at that concentration, not a potency): 102%
For compound 3 the middle estimate is 9 percentage points below the measured one; the measured number falls inside the stated range.
By their numbers in this assay, from the lowest: compounds 2, 1 and 3 (each within the scatter of the next).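

Putting a methoxy in place of hydrogen on this aromatic carbon, ortho to a methoxy group and meta to a large group, gives in this assay a step of a number 10 percentage points higher from compound 2 to compound 3 (within the scatter). Among these compounds, this is the first measured step at this position, and it shows that on this read-out the added methoxy cannot be told apart from the hydrogen it replaces. The test uses a single concentration, so this step says nothing about potency. No other measurement here helps to interpret it.

The compounds shown leave open whether a different group on this same carbon, such as a hydroxyl, an amine or a fluorine atom, would give a step beyond the scatter. They also leave open whether compound 2 and compound 3 would separate at a higher concentration.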